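Compound 3 to compound 4: a series at the limit

The source may report more compounds than this note shows. Statements on the series, on what has been measured and on what is new or still open speak of the compounds shown alone.

In a functional assay on PC-3 cells (Homo sapiens) for inhibition, read by MTT assay, with stated times of 18 h and 4 h (on this read-out lower numbers stand for stronger inhibition and higher numbers for weaker inhibition), compound 3 `CCCCCCOP(=O)(O)OCCSC(=S)N1CCCC1` gives > 100000 nM, which is a limit and not a number. Compound 2 `CCCCCCOP(=O)(O)OCCSC(=S)N1CCCCCC1` gives > 100000 nM, also a limit. Compound 1 `CCCCCCCCOP(=O)(O)OCCSC(=S)N1CCN(C)CC1`, which carries 4-methylpiperazin-1-yl on its thiocarbonyl carbon, gives > 100000 nM, again a limit. Among the compounds with values here, the only measured step that bears on the change is a step that the two limits leave unreadable from compound 2 to compound 3, so it offers no size to carry forward.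

Compound 4 `CCCCCCOP(=O)(O)OCCSC(=S)N1CCN(C)CC1` has 4-methylpiperazin-1-yl in place of pyrrolidin-1-yl on a thiocarbonyl carbon.

No step beyond the scatter is expected in this assay, in either direction, because the limit of > 100000 nM in this assay, at which 3 of the 3 values shown sit, is all the series shows so far. A reported limit is the likeliest outcome. The expected change is a step that the limit leaves unreadable from compound 3 to compound 4, an estimate that implies no real shift. For compound 4 the estimated value is 120000 nM, with an expected range from 50000 nM to 300000 nM.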

Compound 4, half-maximal inhibitory concentration: > 100000 nM
Compound 4: no number, only a limit; the forecaster's own chance of this, stated with the estimate: 85%; the middle value is on the limit's open side.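

In this assay compound 4 gives > 100000 nM, a limit and not a number. The steps from compounds 1, 2 and 3 to compound 4 therefore cannot be read. The compounds shown leave open how strongly any of them inhibits, and whether any change on the shared core alters it: the limit of > 100000 nM in this assay, at which 4 of the 4 values shown sit.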